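Swapping a fluorobenzyl arm for a chlorobenzyl arm

The source may hold more compounds than are shown below. What is called first, only, known or untested is meant among the compounds shown, and "the series" means these compounds.

Measured so far:
Compound 1 `Cc1cc(Nc2nc(Cl)nc3[nH]ncc23)n[nH]1`: 5940 nM
Compound 2 `Cc1cc(Nc2nc(NCc3ccccc3F)nc3[nH]ncc23)n[nH]1`: 389 nM
Compound 3 `Cc1cc(Nc2nc(NCc3cccc(F)c3)nc3[nH]ncc23)n[nH]1`: 458 nM

All three share one core, and they were tested in an assay on isolated protein for inhibition of serine/threonine-protein kinase PAK 4 (Homo sapiens), read by HTRF, with a stated time of 60 min; on this read-out lower numbers stand for stronger inhibition and higher numbers for weaker inhibition. Compound 1 carries only a chlorine on that core and gives 5940 nM. Compound 2, where a 2-fluorobenzyl group replaces the chlorine, stands at 389 nM, far from compound 1. Compound 3 carries a 3-fluorobenzyl group instead, and the step of a 1.2-fold higher number from compound 2 to compound 3 (0.07 log units; within the scatter) is within the scatter, so compounds 2 and 3 cannot be told apart on this read-out.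

Compound 4 `Cc1cc(Nc2nc(NCc3cccc(Cl)c3)nc3[nH]ncc23)n[nH]1` has not yet been measured. It differs from compound 2 in one place: 3-chlorophenyl in place of 2-fluorophenyl on a saturated chain carbon bound to a nitrogen on an aromatic ring. Within the data shown here, the only step that bears on this change is the move of the fluorine from compound 2 to compound 3, which left the number essentially unchanged; no measured pair shows what a chlorine in place of a fluorine on this ring does. Compound 4 is therefore expected to stay close to compound 2, with a step of a 1.1-fold higher number from compound 2 to compound 4 (0.03 log units; within the scatter) that lies within the scatter. The estimate for compound 4 in this assay is 420 nM, within a range from 150 nM to 1200 nM.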

Compound 4, half-maximal inhibitory concentration: 611 nM
Compound 4: middle estimate off by 1.5-fold (0.16 log units), on the low side; the measured number falls inside the stated range.
By their numbers in this assay, from the lowest: compounds 2, 3 and 4 (each within the scatter of the next); then compound 1.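

Among these compounds, putting chloro in place of fluoro on an aromatic carbon, a change no earlier pair covered, gives a 1.3-fold higher number from compound 3 to compound 4 (0.13 log units; within the scatter) and so does not separate the two atoms on this read-out. The wider change from 2-fluorobenzyl to 3-chlorobenzyl gives a 1.6-fold higher number from compound 2 to compound 4 (0.20 log units; within the scatter) and is equally unreadable, so compounds 2, 3 and 4 cannot be told apart and this arm has so far kept its number through all three versions. Nothing measured here explains this flat result.

On these data alone, only fluoro and chloro appear on this ring, so it remains open whether the ring needs any such atom at all, as a plain benzyl group would show. Also open, as far as these compounds go, is whether an amine or a carboxylic acid on the ring, or a longer chain between the ring and the nitrogen, would move the number beyond the scatter.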